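The compounds below may be only part of what the source reports. "The series", "measured", "known", "first", "only" and "open" are said of these compounds alone.

Measured compounds, with their values in a functional assay on MGC-803 cells (Homo sapiens) for inhibition, read by MTT assay, with a stated time of 72 h; a higher number here means a weaker inhibitor, a lower number a stronger inhibitor:

Compound 1 `CCc1cccc(NC(=O)CSc2nc(Nc3ccccc3)c3ccccc3n2)c1` gives 15800 nM.
Compound 2 `C=CC(=O)Nc1cccc(NC(=O)CSc2nc(Nc3ccccc3)c3ccccc3n2)c1` gives 7310 nM.
Compound 3 `O=C(CSc1nc(Nc2ccccc2)c2ccccc2n1)Nc1ccc(C(F)(F)F)cc1` gives 8670 nM.

Compound 1 has the highest number of the three; the gap to compound 3 lies within the scatter, and only the gap to compound 2 lies beyond it. Both measured steps start from compound 1 and change the aryl group on the amide-type nitrogen: a 2.2-fold lower number from compound 1 to compound 2 (0.33 log units; beyond the scatter), and a 1.8-fold lower number from compound 1 to compound 3 (0.26 log units; within the scatter). Between compound 2 and compound 3 the step is a 1.2-fold higher number from compound 2 to compound 3 (0.07 log units; within the scatter).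

Compound 4 `O=C(CSc1nc(Nc2ccccc2)c2ccccc2n1)Nc1ccc(F)c(Cl)c1` is not yet measured in this assay. Its change from compound 1 is 3-chloro-4-fluorophenyl in place of 3-ethylphenyl on an amide-type nitrogen. For the measured compounds named here, the step that bears most directly on it is the exchange of one aryl group for another on the same nitrogen, as in compound 3, which gave a 1.8-fold lower number from compound 1 to compound 3 (0.26 log units; within the scatter); compound 2 gave the only step beyond the scatter. A step of similar modest size, toward a lower number, or none beyond the scatter, is therefore expected: a 1.6-fold lower number from compound 1 to compound 4 (0.20 log units; within the scatter). For compound 4 a value of 10000 nM is estimated, within a range of 4000 nM to 25000 nM.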

Compound 4, half-maximal inhibitory concentration: 20900 nM
Estimate against measurement, compound 4: 2.1-fold (0.32 log units) below; the range from low to high includes it.
By their numbers in this assay, from the lowest: compounds 2, 3, 1 and 4 (each within the scatter of the next, the first and the last beyond it).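

In this assay, exchanging the aryl group on the amide-type nitrogen does not always lower the number: in a 1.3-fold higher number from compound 1 to compound 4 (0.12 log units; within the scatter), 3-chloro-4-fluorophenyl stands level with 3-ethylphenyl. The choice of aryl group can still matter, as shown by a 2.4-fold higher number from compound 3 to compound 4 (0.38 log units; beyond the scatter) and by a 2.9-fold higher number from compound 2 to compound 4 (0.46 log units; beyond the scatter), so compound 4 is separated from two aryl variants, although compound 3 and compound 2 remain within the scatter of each other. No available evidence accounts for these differences.

Still open, as far as these compounds go, is how an aryl group carrying an amine or a carboxylic acid would compare at this nitrogen. The compounds shown also leave open whether a saturated propanoylamino group would match the vinylcarbonylamino group of compound 2.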